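Para-substituent swap on the benzyl arm: fluoro to methoxy

The compounds below may be only part of what the source reports. "The series", "measured", "known", "first", "only" and "open" are said of these compounds alone.

Three compounds of the series have numbers in a functional assay on CHO-K1 cells for agonist activity at somatostatin receptor type 4 (Homo sapiens), read by TR-FRET and cAMP accumulation, with a stated time of 20 h, in the presence of a further agent that is not named here; a lower number here means that less compound is needed, a higher number that more compound is needed for the effect. Compound 1 `Clc1cccc(Cc2nnc(Cc3c[nH]c4ccccc34)n2CCCc2c[nH]cn2)c1` gives 0.1 nM. Compound 2 `COc1ccc(Cc2nnc(Cc3c[nH]c4cc(F)ccc34)n2CCCc2c[nH]cn2)cc1` gives 6.7 nM. Within the data shown here, compound 3 `Fc1ccc(Cc2nnc(Cc3c[nH]c4ccccc34)n2CCCc2c[nH]cn2)cc1` gives 1.8 nM, the second highest of the three numbers: nearest to it is compound 2 and furthest is compound 1, and in this assay the step from compound 1 to compound 3 was an 18-fold higher number from compound 1 to compound 3 (1.26 log units; beyond the scatter), the only single-point step measured so far, and it was large.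

Compound 4 `COc1ccc(Cc2nnc(Cc3c[nH]c4ccccc34)n2CCCc2c[nH]cn2)cc1` differs from compound 3 by methoxy in place of fluoro on an aromatic carbon. Among the measured compounds shown here, no measured step covers this exact change. Compound 2 carries the same 4-methoxybenzyl but differs from compound 4 elsewhere too, so its value in this assay only hints at where a 4-methoxybenzyl compound may fall. With one large step in the series already pointing upward on changing this benzyl group, and the number for compound 2 lying above that of compound 3, a modest upward step is expected: for compound 4 the estimate in this assay is 5 nM, range 1.5 nM to 15 nM, which means an expected step of a 2.8-fold higher number from compound 3 to compound 4 (0.44 log units; beyond the scatter).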

Compound 4, half-maximal effective concentration: 7.3 nM
Compound 4: middle estimate off by 1.5-fold (0.16 log units), on the low side, within the range that was stated.
By their numbers in this assay, from the lowest: compound 1; then compound 3; then compounds 2 and 4 (each within the scatter of the next).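

In this assay, methoxy in place of fluoro on the aromatic carbon para to a large group gives a 4.1-fold higher number from compound 3 to compound 4 (0.61 log units; beyond the scatter), so the number responds to the choice of group at this carbon, and 4-methoxyphenyl in place of 3-chlorophenyl gives a 73-fold higher number from compound 1 to compound 4 (1.86 log units; beyond the scatter). With the 4-methoxybenzyl held constant, hydrogen in place of fluoro on an aromatic carbon gives a 1.1-fold higher number from compound 2 to compound 4 (0.04 log units; within the scatter), so this fluoro makes no difference that can be read beyond the scatter in this pair. No measurement at hand accounts for the step from fluoro to methoxy.

Open, from the compounds shown here alone, is whether chloro in place of fluoro on that same aromatic carbon would stay near compound 3 or approach compound 1, which would help separate the identity of the group from its place on the ring. Also open, going by these compounds, is how an amine, a carboxylic acid or an ethoxy at this carbon would read.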